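The source may hold more compounds than are shown below. What is called first, only, known or untested is meant among the compounds shown, and "the series" means these compounds.

Measured compounds:
Compound 1, `CCc1cccc(CC)c1-n1nncc1CN1C(=O)C2(C(C#N)=C(N)Oc3c(N)cc4nc5ccccc5nc4c32)c2ccccc21`: 37600 nM
Compound 2, `N#CC1=C(N)Oc2c(N)cc3nc4ccccc4nc3c2C12C(=O)N(Cc1cnnn1-c1ccc(Cl)cc1Cl)c1ccccc12`: a limit of the assay, > 50000 nM
Compound 3, `Cc1ccc(Cl)cc1-n1nncc1CN1C(=O)C2(C(C#N)=C(N)Oc3c(N)cc4nc5ccccc5nc4c32)c2ccccc21`: 37200 nM

In a functional assay on HCT-116 cells (Homo sapiens) for antiproliferative activity, read by MTT assay, with a stated time of 48 h (on this read-out higher numbers stand for weaker inhibition and lower numbers for stronger inhibition), compound 3 holds the lower of the two numbers shown, with compound 1 as its nearest neighbour; the step of a 1.0-fold lower number from compound 1 to compound 3 (0.00 log units; within the scatter) lies within the scatter. Compound 2 gives only a limit, as noted (the limit of > 50000 nM in this assay, at which 1 of the 3 values shown sits), so that the step of an at least 1.3-fold lower number from compound 2 to compound 3 (0.12 log units; that floor lies within the scatter) has a floor that also lies within the scatter.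

Compound 4, `COc1cc(-n2nncc2CN2C(=O)C3(C(C#N)=C(N)Oc4c(N)cc5nc6ccccc6nc5c43)c3ccccc32)c(OC)cc1Cl`, differs from compound 3 at the same position that varies across all three measured compounds: 4-chloro-2,5-dimethoxyphenyl in place of 5-chloro-2-methylphenyl on an aromatic nitrogen. Among the compounds with values here, the steps that bear on this change are the three exchanges of the group on the aromatic nitrogen, an at least 1.3-fold higher number from compound 1 to compound 2 (0.12 log units; that floor lies within the scatter), a 1.0-fold lower number from compound 1 to compound 3 (0.00 log units; within the scatter) and an at least 1.3-fold lower number from compound 2 to compound 3 (0.12 log units; that floor lies within the scatter), none of which reached beyond the scatter. Within the data shown here, with nothing among the measured compounds pointing in either direction, compound 4 is expected to stay close to compound 3, with an estimated step of a 1.0-fold lower number from compound 3 to compound 4 (0.00 log units; within the scatter) that does not exceed the scatter. The estimate for compound 4 in this assay is therefore 37000 nM, expected to fall between 15000 nM and 90000 nM, with a real chance that only a limit is reported.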

Compound 4, half-maximal inhibitory concentration: > 50000 nM
Compound 4: only a limit was reported; the forecaster's own chance of this, stated with the estimate: 35%; middle value at least 1.3-fold (0.13 log units) from the limit.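

In this assay compound 4 gives only a limit of the assay, > 50000 nM, and so joins compound 2 at that limit: the limit of > 50000 nM in this assay, at which 2 of the 4 values shown sit. The new steps, an at least 1.3-fold higher number from compound 3 to compound 4 (0.12 log units; that floor lies within the scatter) and an at least 1.3-fold higher number from compound 1 to compound 4 (0.12 log units; that floor lies within the scatter), give floors only, so 4-chloro-2,5-dimethoxyphenyl, the only group here that carries oxygen, is not shown to differ from 5-chloro-2-methylphenyl or 2,6-diethylphenyl; the step between compound 2 and compound 4 cannot be read, as both values are limits. With this oxygen-bearing group included, no readable exchange on the aromatic nitrogen has yet produced a step beyond the scatter.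

From the compounds shown here alone, how far compound 2 and compound 4 actually lie from compound 1 and compound 3 remains open, and with it whether the four groups differ at all. Also open, going by these compounds, is whether a plain phenyl, or a phenyl ring carrying an amine or a carboxylic acid, would move the number beyond the scatter on this shared core.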